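Permeability of a Benzyloxycarbonyl Analogue in the Caco-2 Series

The source may hold more compounds than are shown below. What is called first, only, known or untested is meant among the compounds shown, and "the series" means these compounds.

Compound 1 `Cn1cncc1CN1CC(N(CC2CCN(C(=O)C3CC3)CC2)S(=O)(=O)c2ccccn2)Cc2cc(C#N)ccc21` is the starting point. In an ADME assay on Caco-2 cells (Homo sapiens) for permeability, in the apical to basolateral direction (a higher number here means that the compound crosses the layer faster, a lower number that the compound crosses the layer more slowly), compound 1 gives 0.5 10^-6 cm/s, the second highest of the three numbers measured. Compound 2 `CCOC(=O)N1CCC(CN(C2Cc3cc(C#N)ccc3N(Cc3cncn3C)C2)S(=O)(=O)c2ccccn2)CC1` gives 2.6 10^-6 cm/s, and compound 3 `Cn1cncc1CN1CC(N(CC2CCN(S(=O)(=O)c3ccccc3)CC2)S(=O)(=O)c2ccccn2)Cc2cc(C#N)ccc21` gives 0.1 10^-6 cm/s. The step of a 5.2-fold higher number from compound 1 to compound 2 (0.72 log units; beyond the scatter) raised the number, while the step of a 5.0-fold lower number from compound 1 to compound 3 (0.70 log units; beyond the scatter) lowered it.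

Compound 4 `Cn1cncc1CN1CC(N(CC2CCN(C(=O)OCc3ccccc3)CC2)S(=O)(=O)c2ccccn2)Cc2cc(C#N)ccc21` is not yet measured. Its change from compound 1 is benzyloxy in place of cyclopropyl on a carbonyl carbon. Among the compounds with values here, the step that bears most on this is the one to compound 2, where an alkoxy group on the same carbonyl carbon went with a higher number, a 5.2-fold higher number from compound 1 to compound 2 (0.72 log units; beyond the scatter). Compound 3 differs in another way and offers less guidance. For compound 4 a modest rise is therefore expected, a 2.4-fold higher number from compound 1 to compound 4 (0.38 log units; beyond the scatter), giving an estimated 1.2 10^-6 cm/s within a range of 0.4 10^-6 cm/s to 4 10^-6 cm/s.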

Compound 4, apparent permeability: 1 10^-6 cm/s
The estimate for compound 4 lay 1.2-fold (0.08 log units) above the measured number, within the range that was stated.
By their numbers in this assay, from the lowest: compound 3; then compounds 1 and 4 (each within the scatter of the next); then compound 2.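

With a 2.0-fold higher number from compound 1 to compound 4 (0.30 log units; within the scatter), benzyloxy and cyclopropyl on this carbonyl carbon cannot be told apart in this assay, so the larger group with its aromatic ring costs nothing measurable here. An oxygen on this carbonyl carbon does not settle the number alone: a 2.6-fold lower number from compound 2 to compound 4 (0.41 log units; beyond the scatter), which sets phenyl against methyl on the chain. The choice of linking group also counts, as a 10-fold higher number from compound 3 to compound 4 (1.00 log units; beyond the scatter) separates two groups that each carry a six-membered aromatic ring. Nothing measured here explains these steps. As far as these compounds go, how an amine or a longer alkoxy chain on this carbonyl carbon would behave remains open.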